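A Fluoro for Methoxy Swap Close to the Assay Limit

The compounds below may be only part of what the source reports. "The series", "measured", "known", "first", "only" and "open" are said of these compounds alone.

Within the data shown here, in a functional assay on SK-OV-3 cells (Homo sapiens) for antiproliferative activity, read by MTT assay, with a stated time of 24 h (a higher number here means a weaker inhibitor, a lower number a stronger inhibitor), compound 1 `COc1cccc(/C=C/C(=O)c2ccc(OC)c3c2OC(C)(C)C=C3)c1` gives 9360 nM, the only true number among the three compounds measured. Compound 2 `COc1cc(OC)c(OC)cc1/C=C/C(=O)c1ccc(OC)c2c1OC(C)(C)C=C2` reaches only a limit, > 10000 nM. Compound 3 `COc1ccc(C(=O)/C=C/c2ccc(F)cc2)c2c1C=CC(C)(C)O2` also reaches only a limit, > 10000 nM. Compound 1 therefore stands close to the limit of > 10000 nM in this assay, at which 2 of the 3 values shown sit.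

Compound 4 `COc1ccc(C(=O)/C=C/c2cccc(F)c2)c2c1C=CC(C)(C)O2` carries fluoro in place of methoxy on an aromatic carbon, turning 3-methoxyphenyl into 3-fluorophenyl. Among the measured compounds shown here, the one measured step bearing on this is an at least 1.0-fold higher number from compound 1 to compound 3 (0.02 log units; that floor lies within the scatter), which also trades the methoxy group for fluoro but gives only a floor. In this assay the expected change is a 1.3-fold higher number from compound 1 to compound 4 (0.11 log units; within the scatter), nothing beyond the scatter, with any drift toward a higher number. Compound 4 is estimated at 12000 nM, within an expected range of 6000 nM to 30000 nM.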

Compound 4, half-maximal inhibitory concentration: > 10000 nM
Compound 4: no number, only a limit; the forecaster's own chance of this, stated with the estimate: 60%; the middle value does not contradict the limit.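

In this assay, going by these compounds, the direct exchange on this aromatic carbon gives an at least 1.0-fold higher number from compound 1 to compound 4 (0.02 log units; that floor lies within the scatter), so the replacement of methoxy by fluoro is known only as a floor and its true size stays open. The step from compound 3 to compound 4 cannot be read, as both values are limits. Compound 4 therefore adds a third compound at the assay limit: the limit of > 10000 nM in this assay, at which 3 of the 4 values shown sit.

The compounds shown leave open whether an amine or a carboxylic acid on this aromatic carbon would give a true number rather than a limit.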